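Lengthening the Side Chain of a Thyroid Receptor Ligand

The source may hold more compounds than are shown below. What is called first, only, known or untested is meant among the compounds shown, and "the series" means these compounds.

Compound 1, `Cc1cc(NC(=O)CC(=O)O)c2c(c1Oc1ccc(O)c(C(O)Cc3ccccc3)c1)CCC2`: 124 nM
Compound 2, `Cc1cc(NC(=O)CC(=O)O)c2c(c1Oc1ccc(O)c(CCc3ccc(F)cc3)c1)CCC2`: 8.2 nM

Within the data shown here, in an in vitro assay on cells for displacement of a labelled ligand from thyroid hormone receptor beta (Homo sapiens), with a stated time of 48 h (on this read-out lower numbers stand for stronger inhibition and higher numbers for weaker inhibition), compound 2 gives 8.2 nM, the lower of the two numbers so far. Among the measured compounds shown here, the only measured step is a 15-fold lower number from compound 1 to compound 2 (1.18 log units; beyond the scatter), which reshaped the side chain that hangs from the phenol ring of the shared core. Compound 3, `Cc1cc(NC(=O)CC(=O)O)c2c(c1Oc1ccc(O)c(CCCc3ccccc3)c1)CCC2`, differs from compound 2 by benzyl in place of 4-fluorophenyl on a saturated chain carbon, two bonds along the chain from an aromatic carbon. For the measured compounds named here, no measured pair shows the effect of dropping the fluorine or of adding one carbon to this chain, so the step from compound 1 to compound 2 bears on it only loosely: it shows that this region tolerates sizeable edits and that they can move the number a lot. With no closer guide, the expectation for compound 3 is a step of about a 1.8-fold higher number from compound 2 to compound 3 (0.26 log units; within the scatter) in this assay, toward a somewhat higher number. Compound 3 is therefore estimated at 15 nM, within a range of 4 nM to 60 nM.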

Compound 3, inhibition constant: 223 nM
Estimate against measurement, compound 3: 15-fold (1.17 log units) below; measured number above the stated range.
By their numbers in this assay, from the lowest: compound 2; then compounds 1 and 3 (each within the scatter of the next).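

In this assay, the change from 2-(4-fluorophenyl)ethyl to 3-phenylpropyl is no small edit: it gives a 27-fold higher number from compound 2 to compound 3 (1.43 log units; beyond the scatter) even though the two groups hold the same count of heavy atoms. The low number of compound 2 therefore does not carry over to every aromatic side chain of similar size at this position. The hydroxyl-bearing chain and the 3-phenylpropyl chain cannot be told apart here, as a 1.8-fold higher number from compound 1 to compound 3 (0.25 log units; within the scatter) shows.

Still open, on these data alone, is whether the fluorine or the chain length drives the large step, since both change at once; 2-phenylethyl and 3-(4-fluorophenyl)propyl are the groups that would separate the two. No measurement offered here explains why the number moves so far.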